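The source may report more compounds than this note shows. Statements on the series, on what has been measured and on what is new or still open speak of the compounds shown alone.

Of the compounds shown here, three have been measured so far in a functional assay on MCF7 cells (Homo sapiens) for inhibition, read by MTT assay, with a stated time of 48 h (a lower number here means a stronger inhibitor of growth, a higher number a weaker inhibitor of growth), and give these values.

- compound 1 `COc1ccc2c(c1)c(C1CC(c3ccccc3)=NN1C(=O)c1ccc(OC)nc1)cn2C` gives 990 nM
- compound 2 `COc1ccc2c(c1)c(C1CC(c3ccc(F)cc3)=NN1C(=O)c1ccc(OC)nc1)cn2C` gives 480 nM
- compound 3 `COc1ccc2c(c1)c(C1CC(c3ccc(Br)cc3)=NN1C(=O)c1ccc(OC)nc1)cn2C` gives 6960 nM

Compound 3 carries the highest number of the three and is the weakest inhibitor of growth here, since its steps to both others lie beyond the scatter. The next compound, compound 4 `COc1ccc2c(c1)c(C1CC(c3cc(OC)c(OC)c(OC)c3)=NN1C(=O)c1ccc(OC)nc1)cn2C`, keeps the rest of the structure and differs at one place only, as follows: 3,4,5-trimethoxyphenyl in place of 4-bromophenyl on a carbon with a double bond to nitrogen. Among the measured compounds shown here, three measured steps bear on this place. Fluoro in place of hydrogen gave a modest 2.1-fold lower number from compound 1 to compound 2 (0.31 log units; beyond the scatter), bromo in place of hydrogen gave a modest 7.0-fold higher number from compound 1 to compound 3 (0.85 log units; beyond the scatter), and bromo in place of fluoro gave a large 15-fold higher number from compound 2 to compound 3 (1.16 log units; beyond the scatter). Compound 3 is thus the high outlier, and the two compounds without bromo sit much lower. For the measured compounds named here, none of these steps involves a methoxy group on this ring, so the data offer no direct precedent and the expectation stays loose. With the 4-bromophenyl group gone, a modest fall towards compound 1 and compound 2 is expected. The expected change is a 7.0-fold lower number from compound 3 to compound 4 (0.84 log units; beyond the scatter), and it could prove smaller or larger. For compound 4 the estimated value is 1000 nM, with an expected range from 150 nM to 6000 nM as its limits.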

Compound 4, concentration for 50% growth inhibition: > 10000 nM
Compound 4 gave a limit, no number; the forecaster's own chance of this, stated with the estimate: 3%; middle value at least 10-fold (1.00 log units) away from the limit.
By their numbers in this assay, from the lowest: compound 2; then compound 1; then compound 3. At a limit, above all of these: compound 4.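

In this assay, the reading for compound 4 is a limit of the assay and not a number: the limit of > 10000 nM in this assay, at which 1 of the 4 values shown sits.

Set against the two more active compounds, the change at this carbon with a double bond to nitrogen is clear: 3,4,5-trimethoxyphenyl in place of 4-fluorophenyl gives an at least 20-fold higher number from compound 2 to compound 4 (1.31 log units; beyond the scatter), and in place of phenyl it gives an at least 10-fold higher number from compound 1 to compound 4 (1.00 log units; beyond the scatter), so this position, which had so far been varied only by a single halogen on the phenyl ring, does not keep its activity with every substituted phenyl group. Against compound 3 the limit says much less, since the step is an at least 1.4-fold higher number from compound 3 to compound 4 (0.15 log units; that floor lies within the scatter), and no order between these two can be stated.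

The compounds shown leave open whether a single methoxy group, as in 4-methoxyphenyl, would fall with the more active pair or with the two weaker compounds. They also leave open where a 4-chlorophenyl or a 4-aminophenyl group would stand in this series, and how far beyond its limit the true value of compound 4 lies.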